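Extending the amide chain of compound 2 with a phenyl

This account rests on a few compounds, and the source may have more. Where it says the series, first, only, none or still open, it means among the compounds named here.

Three close analogues of one shared core have been measured in an assay on isolated protein for displacement of a labelled ligand from Adrenergic receptor alpha-1 (Rattus norvegicus); a higher number here means a weaker inhibitor, a lower number a stronger inhibitor. Compound 1 `CCCCNC(=O)C1CCCN(c2nc(N)c3cc(OC)c(OC)cc3n2)C1` gives 8.25 nM, compound 2 `COc1cc2nc(N3CCC(C(=O)NCCO)CC3)nc(N)c2cc1OC` gives 1.73 nM, and compound 3 `CCN(CC)C(=O)C1CCCN(c2nc(N)c3cc(OC)c(OC)cc3n2)C1` gives 117 nM. Compound 2 thus stands lowest of the three numbers; the nearest to it is compound 1, and the gap to compound 3 is the widest.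

Among the compounds with values here, the only single-point step among them runs from compound 1 to compound 3, where a 14-fold higher number from compound 1 to compound 3 (1.15 log units; beyond the scatter) changed the group on the amide nitrogen and moved the number a long way. Compound 2 and compound 1 differ in more than one place, so their values are only compared, not read as a step.

Compound 4 `COc1cc2nc(N3CCC(C(=O)NCCOc4ccccc4)CC3)nc(N)c2cc1OC` is compound 2 with phenyl in place of hydrogen on an oxygen on a saturated carbon. Within the data shown here, the one measured step concerns the amide substituent as well, and it shows that this region can swing this assay strongly. The step from compound 2 to compound 4 is therefore expected to be of a modest size, most likely slightly upward, as a 1.7-fold higher number from compound 2 to compound 4 (0.24 log units; within the scatter), with wide uncertainty. For compound 4 the estimated value is 3 nM, within a range of 0.6 nM to 15 nM.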

Compound 4, inhibition constant: 0.42 nM
Compound 4: the middle estimate sits 7.1-fold (0.85 log units) above what was measured; the whole stated range lies above it.
By their numbers in this assay, from the lowest: compound 4; then compound 2; then compound 1; then compound 3.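

In this assay the far end of the amide chain proves open to a large addition: replacing hydroxy with phenoxy, which puts one six-membered aromatic ring of carbon only on the oxygen of the 2-hydroxyethyl chain, gives a 4.1-fold lower number from compound 2 to compound 4 (0.61 log units; beyond the scatter) and so takes the number down rather than up. Within the data shown here, the only earlier step, a 14-fold higher number from compound 1 to compound 3 (1.15 log units; beyond the scatter), was a change on the amide nitrogen of a different compound pair and went the other way, so these two changes on the amide side do not move the number in the same direction, and the earlier step says little about how the end of the chain behaves. Nothing available explains why the number fell with this change.

The phenyl entered and the hydroxy hydrogen left in the same step, so the two cannot be told apart here; a methoxy on the same oxygen would begin to separate them. Also open, from the compounds shown here alone, is how far the gain extends to a benzyl in place of the phenyl, a chlorophenyl, or a longer chain between the amide nitrogen and the phenoxy.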